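This account rests on a few compounds, and the source may have more. Where it says the series, first, only, none or still open, it means among the compounds named here.

Measured so far in a functional assay on the whole organism (strain Swiss) with Mus musculus as the target, with a stated time of 30 min; a higher number here means that more compound is needed for the effect, a lower number that less compound is needed:
compound 1 `CC(C(=O)Nc1ccccc1)N1C(=O)CCC1=O` gives 75.4 mg/kg
compound 2 `CC(C(=O)Nc1cccc(Cl)c1)N1C(=O)CCC1=O` gives 87.7 mg/kg

Compound 1 stands at the lowest of the two numbers in this assay; its nearest neighbour is compound 2, and the step of a 1.2-fold higher number from compound 1 to compound 2 (0.07 log units; within the scatter) is within the scatter, so the two show no difference of order.

The next compound, compound 3 `CCC(C(=O)Nc1ccccc1)N1C(=O)CCC1=O`, differs from compound 1 by methyl in place of hydrogen on a saturated chain carbon, two bonds along the chain from an amide-type nitrogen in a ring and a carbonyl carbon. Among the measured compounds shown here, the only measured step, a 1.2-fold higher number from compound 1 to compound 2 (0.07 log units; within the scatter), concerns a substituent on the aromatic ring and not the saturated chain, so it does not bear directly on this change. For the measured compounds named here, no measured pair probes a chain change at all, and no step beyond the scatter has been seen. A step of a 1.0-fold lower number from compound 1 to compound 3 (0.00 log units; within the scatter) in this assay is therefore expected, i.e. none beyond the scatter. For compound 3 the estimate in this assay is 75 mg/kg, with a range from 40 mg/kg to 140 mg/kg.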

Compound 3, dose for half-maximal effect: 75.4 mg/kg
Compound 3: middle estimate off by 1.0-fold (0.00 log units), on the low side; the measured number falls inside the stated range.
By their numbers in this assay, from the lowest: compounds 1, 3 and 2 (each within the scatter of the next).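

In this assay, among the compounds shown here, methyl in place of hydrogen on the saturated chain carbon gives no change at the digits printed from compound 1 to compound 3 (within the scatter), the first reading for the chain rather than the aromatic ring. In this assay, the position therefore takes the extra carbon, read as methyl to ethyl, with no step beyond the scatter, so the chain carbon joins the aromatic carbon of compound 2 as a site where one change has left the number within the scatter. No supporting measurement is available to account for this result.

Open, on these data alone, is whether a longer chain such as propyl, a branched group such as isopropyl, or an amine or carboxylic acid at this carbon would also stay within the scatter. Also open, as far as these compounds go, is how the ethyl of compound 3 and the chloro of compound 2 behave together on the shared core.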